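The source may hold more compounds than are shown below. What is called first, only, known or untested is meant among the compounds shown, and "the series" means these compounds.

Compound 1 `COc1ccc(-c2cc(/C=C/C(=O)c3ccc(N)cc3)[nH]n2)cc1` is examined in a functional assay on SR cells (Homo sapiens) for cytotoxicity, read by sulforhodamine B assay, with a stated time of 48 h, tested at 0.01 uM (a higher number here means a weaker effect of the compound at the concentration tested, a lower number a stronger effect), where compound 1 gives 94%. Two companions with a different core substitution were run alongside it: in this assay compound 2 `COc1cc(-c2cc(/C=C/C(=O)c3ccc(Cl)c(Cl)c3)[nH]n2)cc(OC)c1OC` gives 104%, and compound 3 `COc1cc(-c2cc(/C=C/C(=O)c3ccc(F)c(F)c3)[nH]n2)cc(OC)c1OC` gives 100%. Going by the values given here, the one step that can be read between them, a number 4 percentage points lower from compound 2 to compound 3 (within the scatter), stays inside the scatter. Compound 1 holds the lowest of the three numbers, but its gap to compound 3 and its gap to compound 2 are both within the scatter, so nothing separates the three beyond the noise of the measurement.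

Compound 4 `COc1ccc(-c2cc(/C=C/C(=O)c3ccc(N)cc3)[nH]n2)cc1OC` has not been measured. It differs from compound 1 by methoxy in place of hydrogen on an aromatic carbon. Among the compounds with values here, no measured step touches this change: the only step available, a number 4 percentage points lower from compound 2 to compound 3 (within the scatter), concerns a halogen swap on the carbonyl-bearing ring and is itself within the scatter. Within the data shown here, with all three measured numbers close to one another and no relevant precedent, the expected step of a number 2 percentage points higher from compound 1 to compound 4 (within the scatter) in this assay is none beyond the scatter. Compound 4 is therefore estimated at 96%, with a range from 85% to 106%.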

Compound 4, a percentage reported as activity, at one concentration (the size of the read-out at that concentration, not a potency): 98%
Estimate against measurement, compound 4: 2 percentage points below, and the stated range covers the measured number.
By their numbers in this assay, from the lowest: compounds 1, 4, 3 and 2 (each within the scatter of the next).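

In this assay, going by these compounds alone, the step gives the first reading at this position on the methoxyphenyl ring, a site that the halogen swap between compound 2 and compound 3 did not touch. Placing a methoxy group on the aromatic carbon ortho to a methoxy group and meta to a large group gives a number 4 percentage points higher from compound 1 to compound 4 (within the scatter), so at the single concentration tested the added group leaves no effect that can be told from the scatter. This is a reading at one concentration and not a potency, and no evidence is available that bears on this result.

The compounds shown leave open whether a different group on this same aromatic carbon, such as a hydroxyl, an ethoxy chain or a dimethylamino group, would give a step beyond the scatter in this assay. As far as these compounds go, it also remains open whether this methoxy group would give the same result at higher concentrations, where the read-out might have more room to separate compound 1 from compound 4.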